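The compounds below may be only part of what the source reports. "The series", "measured", "known", "first", "only" and "open" are said of these compounds alone.

Measured compounds:

Compound 1 `COc1ccc(-c2nn3cc(-c4cccc(N)c4)nc3s2)cc1` gives 74000 nM in a functional assay on FM3A cells (Mus musculus) for inhibition, read by cell counting, with a stated time of 2 days; on this read-out higher numbers stand for weaker inhibition and lower numbers for stronger inhibition.
Compound 2 `C=C(Br)C(=O)Nc1cccc(-c2cn3nc(-c4ccc(OC)cc4)sc3n2)c1` gives 890 nM in this assay.
Compound 3 `C=C(Br)C(=O)Nc1cccc(-c2cn3nc(-c4ccc(Cl)cc4)sc3n2)c1` gives 2000 nM in this assay.

Compound 2 and compound 1 share one core and differ in a single place: hydrogen in place of (1-bromoethenyl)carbonyl on a nitrogen on an aromatic ring. That change made a step of an 83-fold higher number from compound 2 to compound 1 (1.92 log units; beyond the scatter), so the compound lacking the (1-bromoethenyl)carbonyl group is a far weaker inhibitor. Compound 3 differs from compound 2 only in the core, where chloro in place of methoxy on an aromatic carbon applies; this made a step of a 2.2-fold higher number from compound 2 to compound 3 (0.35 log units; beyond the scatter).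

Compound 4 `Nc1cccc(-c2cn3nc(-c4ccc(Cl)cc4)sc3n2)c1` has not yet been measured. It differs from compound 3 as hydrogen in place of (1-bromoethenyl)carbonyl on a nitrogen on an aromatic ring. The place of this change is described in exactly the same words as for the pair of compound 2 and compound 1, so it is the same change carried out on the core that carries chloro instead of methoxy. Because the step of an 83-fold higher number from compound 2 to compound 1 (1.92 log units; beyond the scatter) was large, a step of similar size is expected for compound 4, a 75-fold higher number from compound 3 to compound 4 (1.88 log units; beyond the scatter). Compound 4 is therefore expected to give about 150000 nM in this assay, estimated to lie between 40000 nM and 500000 nM.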

Compound 4, half-maximal inhibitory concentration: 160000 nM
Compound 4: the middle estimate sits 1.1-fold (0.03 log units) below what was measured; low and high end bracket the measured number.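

Taking the (1-bromoethenyl)carbonyl group off the nitrogen weakened inhibition in this assay by much the same amount on the chloro core as on the methoxy core, with an 80-fold higher number from compound 3 to compound 4 (1.90 log units; beyond the scatter): the same change on two cores in this assay, an 83-fold higher number (1.92 log units; beyond the scatter) from compound 2 to compound 1 and an 80-fold higher number (1.90 log units; beyond the scatter) from compound 3 to compound 4, 1.0-fold (0.02 log units) apart, within the scatter of two such steps

The swap of methoxy for chloro also carried over to the compounds without that group, with a 2.2-fold higher number from compound 1 to compound 4 (0.33 log units; beyond the scatter): the same change on two cores in this assay, a 2.2-fold higher number (0.35 log units; beyond the scatter) from compound 2 to compound 3 and a 2.2-fold higher number (0.33 log units; beyond the scatter) from compound 1 to compound 4, 1.0-fold (0.02 log units) apart, within the scatter of two such steps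

Across these four compounds, then, each change kept its size whichever form the other place took, but this rests on just two examples per change in a single assay, so it neither explains the size of either step nor shows that they would carry over to other cores.

The compounds shown leave open whether the bromine itself matters, which an acryloyl or acetyl group on the same nitrogen could test. They also leave open whether the steps would hold with a fluoro or a dimethylamino group in place of chloro or methoxy.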